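Trading Piperidine for Methylpiperazine on a Shared Core

The source may report more compounds than this note shows. Statements on the series, on what has been measured and on what is new or still open speak of the compounds shown alone.

Of the compounds shown here, two have been measured in a functional assay on A549 cells (Homo sapiens) for inhibition, read by MTT assay, with a stated time of 72 h; a higher number here means a weaker inhibitor, a lower number a stronger inhibitor. Compound 1 `COc1cc2c(Oc3ccc(NC(=O)c4nn(-c5ccccc5C)c(=O)cc4C)cc3F)ccnc2cc1OCCCN1CCN(C)CC1` gives 2830 nM in this assay. Compound 2 `COc1ccc(-n2nc(C(=O)Nc3ccc(Oc4ccnc5cc(OCCCN6CCCCC6)c(OC)cc45)c(F)c3)c(C)cc2=O)cc1` gives 1500 nM in this assay. The number for compound 2 is the lower of the two, but the gap to compound 1 lies within the usual scatter of repeated measurements, so the two values show no real separation. Among the measured compounds shown here, compound 1 and compound 2 differ from each other in more than one place, so no single step connects them.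

Compound 3 `COc1ccc(-n2nc(C(=O)Nc3ccc(Oc4ccnc5cc(OCCCN6CCN(C)CC6)c(OC)cc45)c(F)c3)c(C)cc2=O)cc1` has not yet been measured. It differs from compound 2 in one place: 4-methylpiperazin-1-yl in place of piperidin-1-yl on a saturated chain carbon, three bonds along the chain from an oxygen on an aromatic ring. For the measured compounds named here, no measured pair in this set isolates that same exchange, so there is no direct precedent for its effect. Going by the values given here, the only guidance is that compound 1, which also carries the 4-methylpiperazin-1-yl group on its chain, gives 2830 nM, a number that sits within the scatter of compound 2. The step of a 1.3-fold higher number from compound 2 to compound 3 (0.12 log units; within the scatter) is therefore expected to be small, with no clear direction beyond the scatter. Compound 3 is estimated at 2000 nM, within a range from 800 nM to 5000 nM.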

Compound 3, half-maximal inhibitory concentration: 2200 nM
Compound 3: middle estimate off by 1.1-fold (0.04 log units), on the low side; the measured number falls inside the stated range.
By their numbers in this assay, from the lowest: compounds 2, 3 and 1 (each within the scatter of the next).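

Among the compounds shown here, compound 3 gives the first clean reading of this position in this assay: with everything else held constant, placing 4-methylpiperazin-1-yl instead of piperidin-1-yl on the saturated chain carbon, three bonds along the chain from an oxygen on an aromatic ring, gives a 1.5-fold higher number from compound 2 to compound 3 (0.17 log units; within the scatter) and so shows no real separation in this cell assay. The same compound also isolates a second exchange, since 4-methoxyphenyl in place of 2-methylphenyl on an aromatic nitrogen gives a 1.3-fold lower number from compound 1 to compound 3 (0.11 log units; within the scatter) and likewise shows no real separation, so neither single change among these compounds moves the read-out measurably. No further data bearing on this result are available to help interpret these two steps.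

From the compounds shown here alone, both readings rest on a single pair each, so it remains open whether the chain end tolerates groups of a different kind, such as morpholin-4-yl, an open-chain dimethylamino group or a carboxylic acid, or a longer chain carrying the same rings. Going by these compounds, on the aromatic nitrogen, it is equally open whether an unsubstituted phenyl ring or a pyridine ring would give a number beyond the scatter.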